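Working notes: the step from compound 2 to compound 3

The source may report more compounds than this note shows. Statements on the series, on what has been measured and on what is new or still open speak of the compounds shown alone.

Measured in a functional assay on SW-620 cells (Homo sapiens) for inhibition, read by MTT assay, with a stated time of 72 h; a lower number here means a stronger inhibitor, a higher number a weaker inhibitor:
compound 1 `COc1cc(NC(C)CCCNC(=O)Nc2cccc(F)c2)c2ncccc2c1`: 27000 nM
compound 2 `COc1cc(NC(C)CCCNC(=O)Nc2cccc(Cl)c2)c2ncccc2c1`: 26000 nM

Compound 2 and compound 1 lie within the scatter of each other, so compound 2 holds no separate rank on these two numbers. The next structure is compound 3 `COc1cc(NC(C)CCCNC(=O)Nc2ccc(Br)cc2)c2ncccc2c1`, which carries 4-bromophenyl in place of 3-chlorophenyl on an amide-type nitrogen. For the measured compounds named here, the only measured step bearing on this change is a 1.0-fold lower number from compound 1 to compound 2 (0.02 log units; within the scatter), with chloro in place of fluoro on an aromatic carbon. Going by the values given here, no measured compound carries 4-bromophenyl, so the evidence is thin. No step beyond the scatter is expected in this assay, in either direction. The estimated step is a 1.1-fold lower number from compound 2 to compound 3 (0.03 log units; within the scatter). For compound 3 the expected value is 24000 nM, with an estimated range of 10000 nM to 50000 nM.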

Compound 3, half-maximal inhibitory concentration: 23000 nM
Compound 3: the middle estimate sits 1.0-fold (0.02 log units) above what was measured, and the stated range covers the measured number.
By their numbers in this assay, from the lowest: compounds 3, 2 and 1 (each within the scatter of the next).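

Replacing 3-chlorophenyl with 4-bromophenyl on the amide-type nitrogen gives, in this assay, a 1.1-fold lower number from compound 2 to compound 3 (0.05 log units; within the scatter), and replacing 3-fluorophenyl gives a 1.2-fold lower number from compound 1 to compound 3 (0.07 log units; within the scatter). Unlike the earlier fluoro-to-chloro step, this change alters both the halogen and its printed ring position, yet it still produces no step beyond the scatter. No supporting data bear on this result.

The compounds shown do not separate the halogen from its ring position, as 4-chlorophenyl would. On these data alone, whether an amine or carboxylic acid on the phenyl ring would give a step beyond the scatter remains open.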